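The source may hold more compounds than are shown below. What is called first, only, known or untested is meant among the compounds shown, and "the series" means these compounds.

Measured in a functional assay on A549 cells (Homo sapiens) for cytotoxicity, read by MTT assay, with a stated time of 48 h; on this read-out higher numbers stand for weaker inhibition and lower numbers for stronger inhibition:
- compound 1 `C=C1C(=O)O[C@H]2CC3=C[C@H](C/C(C)=C/[C@@H](OC(=O)c4ccc([N+](=O)[O-])cc4)[C@H]12)OC3=O`: > 10000 nM (a limit of the assay, not a number)
- compound 2 `C=C1C(=O)O[C@H]2CC3=C[C@H](C/C(C)=C/[C@@H](OC(=O)CCCCC)[C@H]12)OC3=O`: > 10000 nM (a limit of the assay, not a number)
- compound 3 `C=C1C(=O)O[C@H]2CC3=C[C@H](C/C(C)=C/[C@@H](OC(=O)C4CC4)[C@H]12)OC3=O`: 3200 nM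

For the measured compounds named here, compound 3, at 3200 nM, gives the only true number of the three. Compound 1 and compound 2 both rest on (the limit of > 10000 nM in this assay, at which 2 of the 3 values shown sit).

Compound 4 `C=C1C(=O)O[C@H]2CC3=C[C@H](C/C(C)=C/[C@@H](OC(=O)c4ccncc4)[C@H]12)OC3=O` carries pyridin-4-yl in place of cyclopropyl on a carbonyl carbon. Going by the values given here, two measured steps bear on this change. The closer one is an at least 3.1-fold lower number from compound 1 to compound 3 (0.49 log units; beyond the scatter), with cyclopropyl in place of 4-nitrophenyl, since the group entering here is also a six-membered aromatic ring. The other is an at least 3.1-fold lower number from compound 2 to compound 3 (0.49 log units; beyond the scatter), with cyclopropyl in place of pentyl. Both steps run towards cyclopropyl, so giving that group up is expected to raise the number in this assay, meaning weaker inhibition. The expected change is a 2.2-fold higher number from compound 3 to compound 4 (0.34 log units; beyond the scatter). A reading reported only as a limit would be no surprise. For compound 4 the estimated value is 7000 nM, with an expected range of 2000 nM to 25000 nM.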

Compound 4, half-maximal inhibitory concentration: > 10000 nM
Compound 4 ended at the assay's limit; the forecaster's own chance of this, stated with the estimate: 50%; at least 1.4-fold (0.15 log units) between middle value and limit.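

In this assay compound 4 gives > 10000 nM, which is a limit of the assay and not a number. Even so, the result can be read as an at least 3.1-fold higher number from compound 3 to compound 4 (0.49 log units; beyond the scatter), so an aromatic ring containing nitrogen on this carbonyl carbon does not keep the activity seen with cyclopropyl. Pyridin-4-yl now joins 4-nitrophenyl and pentyl, which leaves cyclopropyl as the only one of the four groups that gives a true number, while the other three end at the same limit: the limit of > 10000 nM in this assay, at which 3 of the 4 values shown sit.

The steps among compound 1, compound 2 and compound 4 cannot be read, as both ends of each are limits. From the compounds shown here alone, it remains open whether a cyclobutyl, an isopropyl or a plain methyl group on this carbonyl carbon would also give a true number, or whether cyclopropyl stands alone.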